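The compounds below may be only part of what the source reports. "The series", "measured", "known", "first", "only" and "open" are said of these compounds alone.

Compound 1 `COc1cccc(-c2c(C)n(Cc3c(F)cccc3F)c(=O)n(C[C@@H](N)C3CCCC3)c2=O)c1F`, compound 2 `COc1cccc(-c2c(C)n(Cc3c(F)cccc3F)c(=O)n(C[C@H](NC(C)C)C3CCCC3)c2=O)c1F` and compound 3 `COc1cccc(-c2c(C)n(Cc3c(F)cccc3F)c(=O)n(C[C@H](N)C3CCCCC3)c2=O)c1F` share one core and differ only in the group on a saturated chain carbon bound to an aromatic nitrogen. In an assay on HEK293 cells for binding affinity to Gonadotropin-releasing hormone receptor (Homo sapiens), read by radioligand binding (a lower number here means a stronger inhibitor, a higher number a weaker inhibitor), compound 1 gives 94 nM, compound 2 gives 12 nM and compound 3 gives 6.5 nM. Compound 3 has the lowest of these three numbers: the step of a 14-fold lower number from compound 1 to compound 3 (1.16 log units; beyond the scatter) lies beyond the scatter, whereas a 1.8-fold lower number from compound 2 to compound 3 (0.27 log units; within the scatter) stays within it, so compound 2 and compound 3 cannot be told apart on these data. Compound 4 `COc1cccc(-c2c(C)n(Cc3c(F)cccc3F)c(=O)n(C[C@H](NC(C)C)C3CCCCC3)c2=O)c1F` is compound 3 with isopropyl in place of hydrogen on an amine nitrogen. The same replacement has been seen once before, on the amino(cyclopentyl)methyl analogue, as a 7.8-fold lower number from compound 1 to compound 2 (0.89 log units; beyond the scatter). Carried over to compound 3, whose number is already low, a somewhat smaller step of the same direction in this assay is expected, namely a 4.3-fold lower number from compound 3 to compound 4 (0.64 log units; beyond the scatter). The estimated value for compound 4 is therefore 1.5 nM, expected to fall between 0.5 nM and 5 nM.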

Compound 4, inhibition constant: 23 nM
Beside the measured number, compound 4's estimate is 15-fold (1.19 log units) below it, and the stated range ends below it.
By their numbers in this assay, from the lowest: compounds 3, 2 and 4 (each within the scatter of the next, the first and the last beyond it); then compound 1.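

Isopropyl on the amine nitrogen does not act the same way on every compound: a 3.5-fold higher number from compound 3 to compound 4 (0.55 log units; beyond the scatter) runs opposite to a 7.8-fold lower number from compound 1 to compound 2 (0.89 log units; beyond the scatter), so the earlier gain does not carry over to the cyclohexyl compounds. Once the isopropyl is in place, cyclohexyl in place of cyclopentyl gives a 1.9-fold higher number from compound 2 to compound 4 (0.28 log units; within the scatter), which is within the scatter, whereas the same two rings on the unsubstituted amines stand much further apart in a 14-fold lower number from compound 1 to compound 3 (1.16 log units; beyond the scatter). The combined change still leaves a gain, with a 4.1-fold lower number from compound 1 to compound 4 (0.61 log units; beyond the scatter), so compound 4 keeps a lower number than compound 1.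

No measurement shown here explains why the isopropyl step changes direction. On these data alone, it also remains open how a methyl or ethyl on the amine nitrogen, or a phenyl ring in place of cyclohexyl, would behave.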